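The source may hold more compounds than are shown below. What is called first, only, known or untested is meant among the compounds shown, and "the series" means these compounds.

Compound 1, `Cc1ccc(C2(CNC(=O)Nc3c(C(C)C)cccc3C(C)C)CCCC2)cc1`: 25 nM
Compound 2, `CC(C)c1cccc(C(C)C)c1NC(=O)NCC1(c2ccc(Cl)cc2)CCCC1`: 32 nM
Compound 3, `COc1ccc(C2(CNC(=O)Nc3c(C(C)C)cccc3C(C)C)CCCC2)cc1`: 31 nM

The three measured compounds share one core and differ only in the group carried on one aromatic carbon. In an assay on microsomes for inhibition of acyl-CoA:cholesterol acyltransferase (Oryctolagus cuniculus) (on this read-out higher numbers stand for weaker inhibition and lower numbers for stronger inhibition), compound 1 gives 25 nM, compound 2 gives 32 nM and compound 3 gives 31 nM. All three numbers lie within the scatter of one another: a 1.3-fold higher number from compound 1 to compound 2 (0.11 log units; within the scatter), a 1.2-fold higher number from compound 1 to compound 3 (0.09 log units; within the scatter) and a 1.0-fold lower number from compound 2 to compound 3 (0.01 log units; within the scatter). On these numbers compound 3 cannot be set apart from compound 1 or from compound 2.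

Compound 4, `CC(C)c1cccc(C(C)C)c1NC(=O)NCC1(c2ccc(N)cc2)CCCC1`, has not yet been measured in this assay. It differs from compound 3 in one place: amino in place of methoxy on an aromatic carbon. Within the data shown here, the steps that bear on this change are the three exchanges already made at the same aromatic carbon, methyl to chloro, methyl to methoxy and chloro to methoxy, and none of them moved the number beyond the scatter. An amino group has not been tried at that place, so the expectation rests on those three compounds only. Compound 4 is therefore expected to stay close to compound 3, and the expected step is a 1.1-fold higher number from compound 3 to compound 4 (0.05 log units; within the scatter), within the scatter. The estimate for compound 4 is 35 nM, with a range from 12 nM to 100 nM.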

Compound 4, half-maximal inhibitory concentration: 29 nM
Estimate against measurement, compound 4: 1.2-fold (0.08 log units) above; the range from low to high includes it.
By their numbers in this assay, from the lowest: compounds 1, 4, 3 and 2 (each within the scatter of the next).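

In this assay, the amino group is the first group shown at this aromatic carbon, para to a large group, that counts a hydrogen-bond donor where methoxy counts none, and the number still stays within the scatter of all three earlier compounds: a 1.1-fold lower number from compound 3 to compound 4 (0.03 log units; within the scatter) and a 1.1-fold lower number from compound 2 to compound 4 (0.04 log units; within the scatter) and a 1.2-fold higher number from compound 1 to compound 4 (0.06 log units; within the scatter). Among these compounds, the flat picture set by methyl, chloro and methoxy therefore extends to a fourth group, and the change from 4-methoxyphenyl to 4-aminophenyl, with its added donor and one heavy atom fewer, gives no step that can be told from repeat measurement, so the four compounds cannot be set apart on this read-out. Nothing measured here offers an explanation for this result.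

The compounds shown do not tell whether this tolerance holds for groups of another kind at the same carbon, such as a carboxylic acid, a dimethylamino group or a longer chain like hexyl. They also leave open whether plain hydrogen at that carbon, or any of these groups moved elsewhere on the same aromatic ring, would keep the number within the same narrow band.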